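The compounds below may be only part of what the source reports. "The series", "measured", "known", "first", "only" and "open" are said of these compounds alone.

Measured so far:

- Compound 1 `Oc1cccc(-c2nccc([C@@]34CCOC[C@@H]3C4)n2)c1`: 4
- Compound 2 `Oc1cccc(-c2nccc([C@]34CCOC[C@H]3C4)n2)c1`: 4
- Compound 3 `CC(C)(c1cc([C@]23CCOC[C@H]2C3)nc(-c2cccc(O)c2)n1)S(C)(=O)=O`: 4.8

These numbers come from a physicochemical assay for lipophilicity; on this read-out higher numbers stand for higher lipophilicity and lower numbers for lower lipophilicity. Compound 2 stands level with compound 1 at the digits shown, and together they hold the lowest number of the three. Compound 3 is the furthest from compound 2.

Compound 4 `Oc1cccc(-c2nccc(C34CCOCC3C4)n2)c1` has not yet been measured. Its difference from compound 2 is this: the two compounds have the same atoms and bonds; at least one stereo element is drawn with a configuration in one of them and without one in the other: 2 of 2 stereo elements differ; a stereocentre at a saturated ring carbon is drawn R in compound 2 and without a configuration in compound 4; a stereocentre at a saturated ring carbon is drawn S in compound 2 and without a configuration in compound 4. In other words, the two compounds have the same atoms and bonds, but a stereocentre at a saturated ring carbon drawn R in compound 2 and another drawn S there are both drawn without a configuration in compound 4.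

The closest guide is the mirror-image step, no change at the digits printed from compound 1 to compound 2 (within the scatter), and it goes with the fact that compounds 1 and 2 differ only in the configuration as drawn. The other measured step, a number 0.80 log units higher from compound 2 to compound 3 (beyond the scatter), comes with 1-methyl-1-(methylsulfonyl)ethyl in place of hydrogen on an aromatic carbon. Compound 4 carries no such change, so that step does not bear on it.

A change of configuration alone has so far left this assay unmoved, so no shift beyond the scatter is expected, in either direction. The expected step is no change at the digits printed from compound 2 to compound 4 (within the scatter). For compound 4 the estimated value is 4, with an expected range from 3.7 to 4.3.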

Compound 4, partition coefficient: 4.1
Beside the measured number, compound 4's estimate is 0.10 log units below it; the range from low to high includes it.
By their numbers in this assay, from the lowest: compounds 1, 2 and 4 (each within the scatter of the next); then compound 3.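

In this assay, among the compounds shown here, the earlier compounds showed only that exchanging one drawn configuration for its mirror image left the number unchanged at the digits printed, and compound 4 adds a third way of drawing the same atoms and bonds, with no configuration at the two saturated ring carbons. The two new steps read a number 0.10 log units higher from compound 2 to compound 4 (within the scatter) and a number 0.10 log units higher from compound 1 to compound 4 (within the scatter), so removing the drawn configuration, like inverting it, gives no difference beyond the scatter in this read-out for the unsubstituted core. These comparisons isolate the stereochemical drawing, with nothing else in the structures to account for a difference: the fact that one of compounds 2 and 4 is drawn with a defined configuration and the other without, at the place where they differ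

The compounds shown leave open whether the same holds for the 1-methyl-1-(methylsulfonyl)ethyl compound, since compound 3 appears in only one drawn configuration. They also leave open whether configuration would still make no difference in this assay if an amine or a carboxylic acid stood on that aromatic carbon in place of hydrogen.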